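Swapping Chloro for Hydroxy on an Aryl Hydrazone

The source may hold more compounds than are shown below. What is called first, only, known or untested is meant among the compounds shown, and "the series" means these compounds.

Of the compounds shown here, two sharing the same core have so far been measured in a physicochemical assay for lipophilicity, measured as octanol-water partition; on this read-out lower numbers stand for lower lipophilicity and higher numbers for higher lipophilicity. Compound 1 `CCOc1ccc(/C=N/NC(=O)COc2cccc3ccccc23)cc1O` gives 3.82 in this assay. Compound 2 `O=C(COc1cccc2ccccc12)N/N=C/c1ccc(Cl)cc1` gives 4.54 in this assay, the higher of the two numbers. Within the data shown here, the gap between compound 2 and compound 1 lies beyond the usual scatter of repeated measurements, so compound 2 stands clearly above its only measured neighbour.

Compound 3 `O=C(COc1cccc2ccccc12)N/N=C/c1ccc(O)cc1` has not yet been measured. It differs from compound 2 in one place: hydroxy in place of chloro on an aromatic carbon. No pair of measured compounds differs by exactly this exchange, so the size of the step cannot be read from the numbers shown. What follows is an expectation only.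

On the basis of the structural change alone, a step in this assay from compound 2 to compound 3 of about a number 1.39 log units lower from compound 2 to compound 3 (beyond the scatter) is expected, downward and well beyond the scatter. Compound 3 is therefore estimated to give 3.15 in this assay, with a likely range from 2.7 to 3.6.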

Compound 3, partition coefficient: 3.73
Beside the measured number, compound 3's estimate is 0.58 log units below it, outside the stated range (above it).
By their numbers in this assay, from the lowest: compounds 3 and 1 (each within the scatter of the next); then compound 2.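

Among these compounds, compound 2 and compound 3 form the first measured pair that differs by this single exchange, so the size of the change can now be read directly. In this assay, replacing chloro with hydroxy on the aromatic carbon para to a large group gives a step of a number 0.81 log units lower from compound 2 to compound 3 (beyond the scatter), showing that this one-atom change at this position is enough to move the read-out by more than the usual scatter of repeated measurements. The exchange removes one chlorine and adds one oxygen, with one hydrogen-bond donor and one hydrogen-bond acceptor, but no measurement shown here explains why the step has this size.

This single pair cannot show whether the same exchange would produce a similar step at another place on the ring or on a different core. It also leaves open how this position would respond to other groups, such as an amine, a carboxylic acid or a longer chain, and so where hydroxy and chloro would fall among a wider set of substituents.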